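Cytotoxicity of modified nucleosides: the step to compound 4

A few compounds are considered here, and "the series" means these few. Any claim that something is new, unique, unknown or untested is made for them only; others in the source may bear on it.

Measured so far in a functional assay on CCRF-CEM cells (Homo sapiens); a higher number here means that more compound is tolerated, a lower number that less compound is tolerated:
compound 1 `Cc1cn([C@@H]2O[C@H](CO[Si](C)(C)C(C)(C)C)[C@@]3(OS(=O)(=O)C=C3NCCC(=O)OCc3ccccc3)[C@H]2O[Si](C)(C)C(C)(C)C)c(=O)n(C)c1=O`: > 250000 nM
compound 2 `Cc1cn([C@@H]2O[C@H](CO[Si](C)(C)C(C)(C)C)[C@@]3(OS(=O)(=O)C=C3NC(=O)c3ccccc3)[C@H]2O[Si](C)(C)C(C)(C)C)c(=O)n(C)c1=O`: 4910 nM
compound 3 `Cc1cn([C@@H]2O[C@@H]3COC(=O)[C@]3(OS(C)(=O)=O)[C@H]2O)c(=O)[nH]c1=O`: 160000 nM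

The value of compound 1 in this assay is a limit, not a number (the limit of > 250000 nM in this assay, at which 1 of the 3 values shown sits). Of the two numbers, compound 2 holds the lower one; compound 3 gives 160000 nM in this assay. Among the measured compounds shown here, the single measured step, an at least 50-fold lower number from compound 1 to compound 2 (1.70 log units; beyond the scatter), concerns the same amine nitrogen as the change now in question. Compound 4 `COC(=O)CNC1=CS(=O)(=O)O[C@@]12[C@@H](CO[Si](C)(C)C(C)(C)C)O[C@@H](n1cc(C)c(=O)n(C)c1=O)[C@@H]2O[Si](C)(C)C(C)(C)C` differs from compound 2 by (methoxycarbonyl)methyl in place of benzoyl on an amine nitrogen, an ester-bearing chain as in compound 1. On the strength of an at least 50-fold lower number from compound 1 to compound 2 (1.70 log units; beyond the scatter), a large move in the direction of a higher number is expected, and the estimated step is a 20-fold higher number from compound 2 to compound 4 (1.31 log units; beyond the scatter). Compound 4 is therefore expected near 100000 nM, within 20000 nM to 250000 nM.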

Compound 4, half-maximal cytotoxic concentration: 96000 nM
Compound 4: the middle estimate sits 1.0-fold (0.02 log units) above what was measured, within the range that was stated.
By their numbers in this assay, from the lowest: compound 2; then compounds 4 and 3 (each within the scatter of the next). At a limit, above all of these: compound 1.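

In this assay, the low number of compound 2 does not carry over to every group on this amine nitrogen: a 20-fold higher number from compound 2 to compound 4 (1.29 log units; beyond the scatter). Among the ester-bearing chains, the shorter one also separates from the longer: an at least 2.6-fold lower number from compound 1 to compound 4 (0.41 log units; beyond the scatter). That step rests on a limit, and its true size stays unknown: the limit of > 250000 nM in this assay, at which 1 of the 4 values shown sits.

Open, as far as these compounds go, is whether the low number of compound 2 follows the aromatic ring or the amide carbonyl; an acetyl group and a benzyl group on this nitrogen would separate the two. Also open, from the compounds shown here alone, is how a free carboxylic acid in place of the ester would read.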